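This account rests on a few compounds, and the source may have more. Where it says the series, first, only, none or still open, it means among the compounds named here.

Of the compounds shown here, two of this study have so far been tested in a functional assay on thoracic aorta for inhibition of Voltage-gated L-type calcium channel (Rattus norvegicus); on this read-out higher numbers stand for weaker inhibition and lower numbers for stronger inhibition. Compound 1 `CC1=NC(C)=C(C(=O)O)C(c2ccccc2[N+](=O)[O-])/C1=C(\O)OC/C=C/c1ccccc1` gives 31 nM in this assay. Compound 2 `CC1=NC(C)=C(C(=O)O)C(c2cccc(Cl)c2)/C1=C(\O)OC/C=C/c1ccc(Cl)cc1` gives 5.8 nM, the lowest of the two numbers; its nearest neighbour, compound 1, gives a higher number, and that gap lies beyond the scatter. Compound 3 `CC1=NC(C)=C(C(=O)O)C(c2cccc(Cl)c2)/C1=C(\O)OCC(=O)Nc1ccccc1` has not yet been measured. It differs from compound 2 in one place: phenylcarbamoyl in place of 2-(4-chlorophenyl)ethenyl on a saturated chain carbon bound to an oxygen on an unsaturated carbon. Among the measured compounds shown here, no measured pair shows this same change, so the expectation rests on the two values alone. A modest rise in the number is expected for compound 3 a 5.2-fold higher number from compound 2 to compound 3 (0.71 log units; beyond the scatter). The estimate for compound 3 is 30 nM, with a range from 8 nM to 120 nM.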

Compound 3, half-maximal inhibitory concentration: 50 nM
Beside the measured number, compound 3's estimate is 1.7-fold (0.22 log units) below it; low and high end bracket the measured number.
By their numbers in this assay, from the lowest: compound 2; then compounds 1 and 3 (each within the scatter of the next).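

Putting phenylcarbamoyl in place of 2-(4-chlorophenyl)ethenyl gives an 8.6-fold higher number from compound 2 to compound 3 (0.94 log units; beyond the scatter) in this assay, so inhibition weakens. This place therefore responds to the identity of its group, even though both groups have the same heavy-atom count and one aromatic ring. Nothing available explains this step.

The change swaps several features at once, so the compounds shown cannot separate the loss of the chlorine from the arrival of the amide. Also open, as far as these compounds go, is how a chlorine on the phenyl ring of phenylcarbamoyl, or a simple amine at this place, would read.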